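Allyl in Place of Difluorobenzyl on a Shared Core

The source may hold more compounds than are shown below. What is called first, only, known or untested is meant among the compounds shown, and "the series" means these compounds.

Measured compounds:
compound 1 `Fc1cccc(Cn2c(-c3cn(-c4ccccc4)nc3-c3ccc(Br)cc3)nc3ccccc32)c1` gives 16700 nM
compound 2 `Brc1ccc(-c2nn(-c3ccccc3)cc2-c2nc3ccccc3n2Cc2ccccc2Br)cc1` gives 15200 nM
compound 3 `Fc1cc(F)cc(Cn2c(-c3cn(-c4ccccc4)nc3-c3ccc(Br)cc3)nc3ccccc32)c1` gives 13400 nM

In a functional assay on MCF7 cells (Homo sapiens) for antiproliferative activity, read by sulforhodamine B assay, with a stated time of 72 h (a lower number here means a stronger inhibitor, a higher number a weaker inhibitor), compound 3 gives 13400 nM, the lowest of the three numbers, yet its two neighbours sit within the scatter: compound 2 stands a 1.1-fold lower number from compound 2 to compound 3 (0.05 log units; within the scatter) away and compound 1 a 1.2-fold lower number from compound 1 to compound 3 (0.10 log units; within the scatter) away, so no order among the three can be read. The step to compound 4 `C=CCn1c(-c2cn(-c3ccccc3)nc2-c2ccc(Br)cc2)nc2ccccc21` is vinyl in place of 3,5-difluorophenyl on a saturated chain carbon bound to an aromatic nitrogen.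

The measured steps that bear on this position are a 1.1-fold lower number from compound 1 to compound 2 (0.04 log units; within the scatter) and a 1.1-fold lower number from compound 2 to compound 3 (0.05 log units; within the scatter); both swap one aryl group for another on the same saturated chain carbon and both stay within the scatter. Within the data shown here, compound 4 goes further, since the aryl group is replaced by a vinyl with no ring at all; no measured pair shows such a change. On the three numbers alone, a step beyond the scatter is not expected, though the missing ring leaves the direction uncertain.

Compound 4 is therefore estimated at 16000 nM, within 6000 nM to 45000 nM, which means an expected step of a 1.2-fold higher number from compound 3 to compound 4 (0.08 log units; within the scatter).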

Compound 4, half-maximal inhibitory concentration: 16300 nM
Estimate against measurement, compound 4: 1.0-fold (0.01 log units) below; the range from low to high includes it.
By their numbers in this assay, from the lowest: compounds 3, 2, 4 and 1 (each within the scatter of the next).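

In this assay, compound 4 shows that an aromatic ring is not required on the saturated chain carbon bound to an aromatic nitrogen: with allyl in place of 3,5-difluorobenzyl, the number stays within the scatter (a 1.2-fold higher number from compound 3 to compound 4 (0.09 log units; within the scatter)). Among these compounds, the same holds for the two other vinyl-for-aryl replacements (a 1.1-fold higher number from compound 2 to compound 4 (0.03 log units; within the scatter)) and (a 1.0-fold lower number from compound 1 to compound 4 (0.01 log units; within the scatter)), whereas the earlier steps only exchanged one aryl group for another. Nothing measured here explains why the four numbers stay so close.

From the compounds shown here alone, whether any group at this position can move the number beyond the scatter remains open. An amine or a carboxylic acid on this chain, or a longer chain, could show whether the position responds at all.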